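A few compounds are considered here, and "the series" means these few. Any claim that something is new, unique, unknown or untested is made for them only; others in the source may bear on it.

Going by the values given here, in a functional assay on CCRF-CEM cells (Homo sapiens) for cytotoxicity, read by cell counting, with a stated time of 3 days (a lower number here means a stronger inhibitor, a higher number a weaker inhibitor), compound 1 `Nc1ccc(/C=C2\SC(=O)N(Cc3ccc(C(F)(F)F)cc3)C2=O)cc1` gives 32000 nM, the only plain number among the two compounds tested. Among the compounds with values here, compound 2 `Cc1ccc(CN2C(=O)S/C(=C\c3cccc(N)c3)C2=O)cc1` differs from compound 1 in two places at once, so no single step joins them and their two values can only be set side by side. Within the data shown here, for compound 2 this assay reports no number but only a limit, > 250000 nM, and compound 2 is thus the one compound that sits at the limit of > 250000 nM in this assay, at which 1 of the 2 values shown sits. Compound 3 `Nc1cccc(/C=C2\SC(=O)N(Cc3ccc(C(F)(F)F)cc3)C2=O)c1` is the next compound, still unmeasured, and it is reached from compound 2 by one change: trifluoromethyl in place of methyl on an aromatic carbon. Among the measured compounds shown here, no measured pair shows this change on its own, so the size of its step is open. Since compound 2 shows only a limit, any step from compound 2 to compound 3 can only be read downward from that limit or not at all, and a modest move is expected, an at least 1.6-fold lower number from compound 2 to compound 3 (0.22 log units; that floor lies within the scatter). For compound 3 the expected value in this assay is 150000 nM, with a range from 40000 nM to 400000 nM, and a fair chance that this assay again reports only a limit.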

Compound 3, half-maximal inhibitory concentration: > 250000 nM
Compound 3: only a limit was reported (the forecaster's own chance of this, stated with the estimate: 45%); at least 1.6-fold (0.22 log units) between middle value and limit.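

In this assay, putting 3-aminophenyl in place of 4-aminophenyl on the double-bonded chain carbon, with the rest of the molecule kept, gives an at least 7.8-fold higher number from compound 1 to compound 3 (0.89 log units; beyond the scatter). Going by these compounds alone, this is the first single change with a size that can be read, and it lies beyond the usual scatter; the trifluoromethyl group alone does not secure a plain number, since compound 1 and compound 3 both carry it and only compound 1 gives one. The step for trifluoromethyl in place of methyl cannot be read, since compound 2 and compound 3 each report only a limit: the limit of > 250000 nM in this assay, at which 2 of the 3 values shown sit.

From the compounds shown here alone, what trifluoromethyl in place of methyl does on its own therefore stays open, and so does whether a compound pairing 4-aminophenyl with methyl would give a plain number. Also open, going by these compounds, is what a hydroxyl group or a carboxylic acid would do in place of the amine on that ring.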